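The source may report more compounds than this note shows. Statements on the series, on what has been measured and on what is new or still open speak of the compounds shown alone.

Working notes on the series. Within the data shown here, in a functional assay on Thorax with Thoracic (Rattus norvegicus) as the target, tested at 40 uM (on this read-out lower numbers stand for a weaker effect and higher numbers for a stronger effect at the one concentration tested), compound 1 `CC(C)(F)[C@@H]1COc2ccc(F)cc2[C@@H]1C#Cc1ccccc1` gives 83% and compound 2 `CC(C)(F)[C@@H]1COc2c(F)cc(F)cc2[C@@H]1C#Cc1ccccc1` gives 65%, the lowest of the two numbers so far; the one measured step, a number 18 percentage points lower from compound 1 to compound 2 (beyond the scatter), is the only guide available. Compound 3 `CC(C)(F)[C@@H]1COc2c(F)cccc2[C@@H]1C#Cc1ccccc1` differs from compound 2 by hydrogen in place of fluoro on an aromatic carbon. Among the measured compounds shown here, no measured step removes this particular fluoro, and the step from compound 1 to compound 2 concerns the other fluoro, so the direction is uncertain; the expected change is estimated as a number 5 percentage points lower from compound 2 to compound 3 (within the scatter), within the scatter. Compound 3 is accordingly expected to give about 60%, in the range 40% to 78%.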

Compound 3, a percentage reported as activity, at one concentration (the size of the read-out at that concentration, not a potency): 92%
Estimate against measurement, compound 3: 32 percentage points below, and the stated range ends below it.
By their numbers in this assay, from the lowest: compound 2; then compounds 1 and 3 (each within the scatter of the next).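

In this assay, hydrogen in place of the fluoro para to a fused ring gives a number 27 percentage points higher from compound 2 to compound 3 (beyond the scatter), so this fluoro counts against the read-out when the second fluoro is present. With a number 18 percentage points lower from compound 1 to compound 2 (beyond the scatter), each single fluoro removal from compound 2 now has a measured step, and both raise the number. No measured data here bear on the reason for this step.

As far as these compounds go, whether a chloro or a methoxy group at this position would behave like fluoro or like hydrogen stays open. From the compounds shown here alone, the effect of this change without the second fluoro also stays open.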